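From a 4-hydroxy-2-methylphenyl group to 4-ethylphenyl

This account rests on a few compounds, and the source may have more. Where it says the series, first, only, none or still open, it means among the compounds named here.

Among the compounds with values here, in a functional assay on RXF 393 cells (Homo sapiens) for inhibition, read by sulforhodamine B assay, with a stated time of 48 h (on this read-out lower numbers stand for stronger inhibition of growth and higher numbers for weaker inhibition of growth), compound 2 `Cc1cc(O)ccc1C1=NN(c2ccc(S(C)(=O)=O)cc2)C(=O)CC1` gives 12800 nM and stands highest of the two numbers so far, above compound 1 `Cc1ccc(C2=NN(c3ccc(S(C)(=O)=O)cc3)C(=O)CC2)cc1` at 630 nM on this read-out. Compound 3 `CCc1ccc(C2=NN(c3ccc(S(C)(=O)=O)cc3)C(=O)CC2)cc1` has 4-ethylphenyl in place of 4-hydroxy-2-methylphenyl on a carbon with a double bond to nitrogen in the shared core. Within the data shown here, one measured step bears on this, the large one a 20-fold higher number from compound 1 to compound 2 (1.31 log units; beyond the scatter) with 4-hydroxy-2-methylphenyl in place of 4-methylphenyl. Compound 3 resembles compound 1 at that place. A large step to a lower number is therefore expected, a 16-fold lower number from compound 2 to compound 3 (1.20 log units; beyond the scatter) by this estimate. Compound 3 is expected at 800 nM within a range from 250 nM to 2500 nM in this estimate.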

Compound 3, concentration for 50% growth inhibition: 2040 nM
Beside the measured number, compound 3's estimate is 2.6-fold (0.41 log units) below it; the range from low to high includes it.
By their numbers in this assay, from the lowest: compound 1; then compound 3; then compound 2.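

The change to 4-ethylphenyl recovers much of the loss seen with 4-hydroxy-2-methylphenyl, with a 6.3-fold lower number from compound 2 to compound 3 (0.80 log units; beyond the scatter) on this position. The recovery is incomplete, and even a small change to the chain matters here: methyl in place of hydrogen on the saturated chain carbon gives a 3.2-fold higher number from compound 1 to compound 3 (0.51 log units; beyond the scatter) in going from 4-methylphenyl to 4-ethylphenyl. No measurement on hand accounts for either step.

As far as these compounds go, whether a propyl chain or a methoxy group in place of that ethyl would raise the number further remains open. So does what the hydroxy and methyl groups of 4-hydroxy-2-methylphenyl each contribute alone.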